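This account rests on a few compounds, and the source may have more. Where it says the series, first, only, none or still open, it means among the compounds named here.

In a functional assay on CLL cells (Homo sapiens) for cytotoxicity, read by MTT assay, with a stated time of 48 h (a higher number here means that more compound is needed for the effect, a lower number that less compound is needed), compound 1 (`C=C(CC)C(=O)c1ccc(OCC(=O)Nc2nc3ccccc3s2)c(Cl)c1Cl`) gives 1500 nM and compound 2 (`C=C(CC)C(=O)c1ccc(OCC(=O)Nc2cccc(C(=O)O)c2)c(Cl)c1Cl`) gives 20600 nM while compound 3 (`C=C(CC)C(=O)c1ccc(OCC(=O)Nc2ccc(C(C)=O)cc2)c(Cl)c1Cl`) gives 3900 nM as the second highest of the three numbers. Compound 4 (`C=C(CC)C(=O)c1ccc(OCC(=O)NCO[N+](=O)[O-])c(Cl)c1Cl`) carries (nitrooxy)methyl in place of 4-acetylphenyl on an amide-type nitrogen. Three measured steps at this nitrogen bear on the change: a 2.6-fold higher number from compound 1 to compound 3 (0.41 log units; beyond the scatter) and a 5.3-fold lower number from compound 2 to compound 3 (0.72 log units; beyond the scatter) are modest and a 14-fold higher number from compound 1 to compound 2 (1.14 log units; beyond the scatter) is large. None of them tests a group without a ring, so no direction can be favoured and no clear step is expected in this assay here. The expected step is a 1.3-fold higher number from compound 3 to compound 4 (0.11 log units; within the scatter) with much uncertainty. For compound 4 the estimate is 5000 nM with 1500 nM to 20000 nM as its expected range.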

Compound 4, half-maximal effective concentration: 4100 nM
For compound 4 the middle estimate is 1.2-fold (0.09 log units) above the measured one; the range from low to high includes it.
By their numbers in this assay, from the lowest: compound 1; then compounds 3 and 4 (each within the scatter of the next); then compound 2.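

For the compounds shown here, the first group here without a ring on the amide-type nitrogen, (nitrooxy)methyl, gives no readable change from 4-acetylphenyl in this assay: a 1.1-fold higher number from compound 3 to compound 4 (0.02 log units; within the scatter). Against the other two groups, the steps are a 5.0-fold lower number from compound 2 to compound 4 (0.70 log units; beyond the scatter) and a 2.7-fold higher number from compound 1 to compound 4 (0.44 log units; beyond the scatter), so a ring at this nitrogen is not required for a number in this range. Nothing measured here explains these steps. The compounds shown leave open whether the nitrooxy part matters or any small chain without a ring would do: a plain propyl chain or a hydroxymethyl group on this nitrogen would separate the two.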